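A few compounds are considered here, and "the series" means these few. Any claim that something is new, unique, unknown or untested is made for them only; others in the source may bear on it.

Two cyclopropylidene-methyl purine analogues bearing a thioether chain have been examined in an ADME assay on CCRF-HSB-2 cells (Homo sapiens) for cytotoxicity, with a stated time of 7 days; a lower number here means that less compound is tolerated, a higher number that more compound is tolerated. Compound 1 `CCCCSc1nc(N)nc2c1ncn2/C=C1/CC1(CO)CO` gives 89000 nM in this assay. Compound 2 `CC(C)CSc1nc(N)nc2c1ncn2/C=C1/CC1(CO)CO` gives 60000 nM. The change from compound 1 to compound 2, isopropyl in place of propyl on a saturated chain carbon bound to a sulfur, produced a 1.5-fold lower number from compound 1 to compound 2 (0.17 log units; within the scatter), so the two values stand together within the scatter and neither can be ranked over the other. Going by the values given here, compound 2 carries the lowest of the two numbers so far, with compound 1 as its nearest neighbour.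

Compound 3 `CCCSc1nc(N)nc2c1ncn2/C=C1/CC1(CO)CO` differs from compound 2 by hydrogen in place of methyl on a saturated chain carbon bound to two saturated chain carbons. Among the compounds with values here, the single measured step, isopropyl in place of propyl, stayed within the scatter; the data hold nothing else bearing on a shortened chain. Compound 3 is therefore expected to stay close to compound 2, a step of a 1.3-fold higher number from compound 2 to compound 3 (0.10 log units; within the scatter), without a change beyond the scatter in either direction. The estimate for compound 3 is 75000 nM, with a range from 35000 nM to 160000 nM.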

Compound 3, half-maximal cytotoxic concentration: 98000 nM
Beside the measured number, compound 3's estimate is 1.3-fold (0.12 log units) below it, within the range that was stated.
By their numbers in this assay, from the lowest: compounds 2, 1 and 3 (each within the scatter of the next).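

In this assay, the change from isobutylsulfanyl to propylsulfanyl, hydrogen in place of methyl on a saturated chain carbon bound to two saturated chain carbons, gives a 1.6-fold higher number from compound 2 to compound 3 (0.21 log units; within the scatter), so losing this branch stays within the scatter. Hydrogen in place of methyl on a saturated chain carbon, three bonds along the chain from a sulfur, gives a 1.1-fold higher number from compound 1 to compound 3 (0.04 log units; within the scatter), so shortening the unbranched chain stays within the scatter as well. The three chains therefore cannot be ranked against one another, and nothing at hand offers an explanation for the result.

The compounds shown leave open how a much longer chain, such as octyl, or a chain ending in an amine or a carboxylic acid would read in this assay. They also leave open what an ether oxygen in place of the sulfur would do.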